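The compounds below may be only part of what the source reports. "The series", "measured", "known", "first", "only" and "open" are said of these compounds alone.

Measured compounds in a functional assay on cells (Panel renal (Carcinoma cell lines), Homo sapiens) for inhibition, read by sulforhodamine B assay, with a stated time of 48 h; a higher number here means a weaker inhibitor of growth, a lower number a stronger inhibitor of growth:
compound 1, `CN1CCN(CCCOc2cccc3nc(Nc4ccc(Cl)c(C(F)(F)F)c4)ccc23)CC1`: 1620 nM
compound 2, `CN1CCN(CCCOc2cccc3nc(Nc4ccc(F)c(F)c4)ccc23)CC1`: 4160 nM
compound 3, `CN1CCN(CCCOc2cccc3nc(Nc4cc(Cl)cc(Cl)c4)ccc23)CC1`: 2070 nM

Compound 3 stands second highest of the three numbers in this assay. Its nearer neighbour is reached by a 1.3-fold higher number from compound 1 to compound 3 (0.11 log units; within the scatter) and its further one by a 2.0-fold lower number from compound 2 to compound 3 (0.30 log units; within the scatter); both steps sit within the scatter, so no order among these three is asserted. Going by the values given here, the one step beyond the scatter in the set is a 2.6-fold higher number from compound 1 to compound 2 (0.41 log units; beyond the scatter), a modest one.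

Compound 4, `CN1CCN(CCCOc2cccc3nc(Nc4cccc(Cl)c4)ccc23)CC1`, is obtained from compound 3 by hydrogen in place of chloro on an aromatic carbon, that is, 3,5-dichlorophenyl becomes 3-chlorophenyl on the shared core. None of the three measured steps removes a single halogen from an otherwise unchanged aryl group; each swaps the whole aryl group, so they bear on this change only loosely. They suggest that varying the halogen pattern on this ring moves the number little, with the lighter-halogen pattern of compound 2 giving the higher number. In this assay, the step from compound 3 to compound 4 is therefore expected to be small, leaning toward a higher number, and most likely within the scatter: a 1.4-fold higher number from compound 3 to compound 4 (0.16 log units; within the scatter). Compound 4 is estimated at 3000 nM in this assay, with a range from 1400 nM to 6500 nM.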

Compound 4, concentration for 50% growth inhibition: 1900 nM
Estimate against measurement, compound 4: 1.6-fold (0.20 log units) above; the measured number falls inside the stated range.
By their numbers in this assay, from the lowest: compounds 1, 4, 3 and 2 (each within the scatter of the next, the first and the last beyond it).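

In this assay, going by these compounds alone, this is the first change of a single halogen on an otherwise unchanged aryl group, and taking one chloro from the 3,5-dichlorophenyl group leaves the number level (a 1.1-fold lower number from compound 3 to compound 4 (0.04 log units; within the scatter)). The 3-chlorophenyl group also stays level with the 4-chloro-3-(trifluoromethyl)phenyl group (a 1.2-fold higher number from compound 1 to compound 4 (0.07 log units; within the scatter)), while it stands apart from the 3,4-difluorophenyl group (a 2.2-fold lower number from compound 2 to compound 4 (0.34 log units; beyond the scatter)), a modest step beyond the scatter, so compound 2 now has two such steps, one to compound 1 and one to compound 4, and compound 3 has none. No measurement bearing on the reason for these results is available.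

As far as these compounds go, whether the remaining chloro contributes at all stays open: an unsubstituted phenyl group would settle that, and a methoxy or nitrile group in its place would show whether a non-halogen group is tolerated there. Also open, from the compounds shown here alone, is how the number responds to changes away from this aryl group, for example a morpholine in place of the methylpiperazine or a longer chain to it.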